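Halogen placement on the cinnamoyl ring: compound 2 to compound 3

The compounds below may be only part of what the source reports. "The series", "measured", "known", "first", "only" and "open" are said of these compounds alone.

Measured so far:
compound 1, `O=C(COc1ccc(C(=O)/C=C/c2ccccc2)cc1)N[C@H]1CCOC1=O`: 56800 nM
compound 2, `O=C(COc1ccc(C(=O)/C=C/c2ccccc2Br)cc1)N[C@H]1CCOC1=O`: 3260 nM

Going by the values given here, compound 2 holds the lowest number of the two in a functional assay on PC-3 cells (Homo sapiens) for antiproliferative activity, read by MTT assay, with a stated time of 72 h; a lower number here means a stronger inhibitor, a higher number a weaker inhibitor; its only neighbour is compound 1, separated by a 17-fold lower number from compound 1 to compound 2 (1.24 log units; beyond the scatter). The next compound, compound 3, `O=C(COc1ccc(C(=O)/C=C/c2cccc(F)c2)cc1)N[C@H]1CCOC1=O`, differs from compound 2 by 3-fluorophenyl in place of 2-bromophenyl on a double-bonded chain carbon bound to a double-bonded chain carbon. Among the compounds with values here, no measured step covers this exchange of one halogen for another at a different spot on the ring; the single step from compound 1 to compound 2 only shows that a halogen on that ring lowered the number strongly. Compound 3 is therefore expected to fall between the two, estimated at 15000 nM (range 4000 nM to 50000 nM). The expected step is a 4.6-fold higher number from compound 2 to compound 3 (0.66 log units; beyond the scatter).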

Compound 3, half-maximal inhibitory concentration: 23200 nM
Compound 3: the middle estimate sits 1.5-fold (0.19 log units) below what was measured; the measured number falls inside the stated range.
By their numbers in this assay, from the lowest: compound 2; then compound 3; then compound 1.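

In this assay, fluoro in place of hydrogen still gives a 2.4-fold lower number from compound 1 to compound 3 (0.39 log units; beyond the scatter) and so lowers the number, but far less than bromo in place of hydrogen, which gives a 17-fold lower number from compound 1 to compound 2 (1.24 log units; beyond the scatter) in the same assay. Replacing 2-bromophenyl with 3-fluorophenyl gives a 7.1-fold higher number from compound 2 to compound 3 (0.85 log units; beyond the scatter) and shows that a halogen on this ring does not guarantee the large drop. No evidence bears on the origin of this difference. The halogen and its location change together in this step, so their contributions remain unseparated. Going by these compounds, whether a methoxy group or an amine on this ring would retain the lower number also remains open.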